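This account rests on a few compounds, and the source may have more. Where it says the series, first, only, none or still open, it means among the compounds named here.

Measured compounds in a functional assay on PC-12 cells (Rattus norvegicus) for cytotoxicity, read by MTT assay, with stated times of 2 h and 24 h, tested at 10 uM; a higher number here means a stronger effect of the compound at the concentration tested, a lower number a weaker effect:
compound 1, `Oc1cc(C(F)(F)F)ccc1-c1nc(-c2ccccc2O)n(-c2ccccc2C(F)(F)F)n1`, gives 92.2%
compound 2, `COc1ccccc1-n1nc(-c2ccc(C(F)(F)F)cc2O)nc1-c1ccccc1O`, gives 96.2%
compound 3, `Oc1cc(C(F)(F)F)ccc1-c1nc(-c2ccccc2O)n(-c2cccc(C(F)(F)F)c2)n1`, gives 99.9%

The three numbers sit close together: a number 4 percentage points higher from compound 1 to compound 2 (within the scatter), a number 7.7 percentage points higher from compound 1 to compound 3 (within the scatter) and a number 3.7 percentage points higher from compound 2 to compound 3 (within the scatter) all fall within the scatter, so no order among compounds 1, 2 and 3 can be read from them.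

Compound 4, `COc1cccc(-n2nc(-c3ccc(C(F)(F)F)cc3O)nc2-c2ccccc2O)c1`, is not yet measured. It differs from compound 3 by methoxy in place of trifluoromethyl on an aromatic carbon. The same kind of change separates compound 1 from compound 2, namely (methoxy in place of trifluoromethyl on an aromatic carbon), where it gave a number 4 percentage points higher from compound 1 to compound 2 (within the scatter). The two changes are not identical in setting: in the earlier pair the place is ortho to a large group, in the new pair it is meta to a large group. The two cores also differ, as compound 3 differs from compound 1 by 3-(trifluoromethyl)phenyl in place of 2-(trifluoromethyl)phenyl on an aromatic nitrogen; that rearrangement itself gave a number 7.7 percentage points higher from compound 1 to compound 3 (within the scatter).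

Given that the one observed instance of the change left the number essentially unchanged, and that compound 3 already reads near the top of the range at 99.9%, the step from compound 3 to compound 4 in this assay is expected to be small, estimated at a number 3.9 percentage points lower from compound 3 to compound 4 (within the scatter). Going by the values given here, compound 4 is therefore estimated at 96%, expected to lie between 86% and 103%, the single precedent being a number 4 percentage points higher from compound 1 to compound 2 (within the scatter).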

Compound 4, a percentage reported as activity, at one concentration (the size of the read-out at that concentration, not a potency): 106%
For compound 4 the middle estimate is 10 percentage points below the measured one, and the stated range ends below it.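

In this assay, methoxy in place of trifluoromethyl on an aromatic carbon can now be read on two cores, and the two readings agree: the same change on two cores in this assay, a number 4 percentage points higher (within the scatter) from compound 1 to compound 2 and a number 6.1 percentage points higher (within the scatter) from compound 3 to compound 4, 2.1 percentage points apart, within the scatter of two such steps

Going by these compounds alone, on these two cores, then, the change carries over without a detectable difference, but this does not establish a direction or a true size for it: a number 6.1 percentage points higher from compound 3 to compound 4 (within the scatter) is one of only two pairs, and both steps lie inside the scatter. The swaps on the aromatic nitrogen give a number 9.8 percentage points higher from compound 2 to compound 4 (within the scatter) for 3-methoxyphenyl in place of 2-methoxyphenyl and a number 13.8 percentage points higher from compound 1 to compound 4 (beyond the scatter) for 3-methoxyphenyl in place of 2-(trifluoromethyl)phenyl, and only the second is beyond the scatter, modestly so, which is a single pair and no rule for the series.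

Among the compounds shown, the aryl group on the aromatic nitrogen carries only trifluoromethyl or methoxy, so how an amine, a carboxylic acid or a longer chain would read in this assay remains open. Going by these compounds, each value also comes from a single tested concentration, and whether the change keeps its size at other concentrations stays open too.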